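Adding a Second Hydroxy Group to Compound 1

A few compounds are considered here, and "the series" means these few. Any claim that something is new, unique, unknown or untested is made for them only; others in the source may bear on it.

Measured so far:
- compound 1, `Oc1ccc(N2CCN(CC(O)COc3cccc4ccccc34)CC2)c(O)c1`, 30300 nM
- compound 2, `Oc1ccccc1N1CCN(CC(O)COc2ccc(O)c3ccccc23)CC1`, 26100 nM
- compound 3, `Oc1ccccc1N1CCN(CC(O)COc2cccc3ccccc23)CC1`, 21700 nM

In a functional assay on PC-3 cells (Homo sapiens) for antiproliferative activity, read by MTT assay, with a stated time of 48 h (on this read-out higher numbers stand for weaker inhibition and lower numbers for stronger inhibition), compound 1 gives 30300 nM, the highest number of the three, although its nearest neighbour compound 2 gives 26100 nM and compound 3 gives 21700 nM, and neither gap is larger than the usual scatter.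

Compound 4, `Oc1ccc(N2CCN(CC(O)COc3ccc(O)c4ccccc34)CC2)c(O)c1`, has not yet been measured. It differs from compound 1 in one place: hydroxy in place of hydrogen on an aromatic carbon

Within the data shown here, the measured step that bears on this is the one from compound 2 to compound 3, where the same hydroxy is removed from the same position of the shared core: a 1.2-fold lower number from compound 2 to compound 3 (0.08 log units; within the scatter). The step from compound 1 to compound 3, a 1.4-fold lower number from compound 1 to compound 3 (0.14 log units; within the scatter), concerns a hydroxy elsewhere and is likewise small. Reversing the change seen between compound 2 and compound 3 therefore suggests no step beyond the scatter in this assay when the hydroxy is added to compound 1.

For compound 4 the expected value is 36000 nM, with an estimated range from 18000 nM to 72000 nM.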

Compound 4, half-maximal inhibitory concentration: 17700 nM
The estimate for compound 4 lay 2.0-fold (0.31 log units) above the measured number, outside the stated range (below it).
By their numbers in this assay, from the lowest: compounds 4, 3, 2 and 1 (each within the scatter of the next).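

Hydroxy in place of hydrogen on the aromatic carbon para to a large group brings a 1.7-fold lower number from compound 1 to compound 4 (0.23 log units; within the scatter) in this assay, so this position accepts the new hydroxy on the core of compound 1 without a step beyond the scatter. The earlier compounds shown here carried at most one of the two added hydroxy groups, whereas compound 4 carries both, and the step that adds the second hydroxy to the other core, a 1.5-fold lower number from compound 2 to compound 4 (0.17 log units; within the scatter), is also small. The same hydroxy at this position, compared on two cores, behaves alike within the scatter: the same change on two cores in this assay, a 1.2-fold lower number (0.08 log units; within the scatter) from compound 2 to compound 3 and a 1.7-fold higher number (0.23 log units; within the scatter) from compound 4 to compound 1, 2.1-fold (0.31 log units) apart, within the scatter of two such steps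

All four numbers sit so close together that no real effect of this hydroxy can be told apart from the scatter. As far as these compounds go, whether a methoxy group, an amine or a carboxylic acid at this same position would give a larger step remains open.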